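Swapping tert-butyl for bromo: an antiproliferative estimate

This account rests on a few compounds, and the source may have more. Where it says the series, first, only, none or still open, it means among the compounds named here.

Values in a functional assay on DU-145 cells (Homo sapiens) for antiproliferative activity, read by MTT assay, with a stated time of 72 h; a lower number here means a stronger inhibitor, a higher number a weaker inhibitor:
Compound 1 `O=C1OCC[C@@H]1NC(=S)SCCOc1cccc2ccccc12`: > 64000 nM (a limit, not a number)
Compound 2 `CC(C)(C)c1ccc(/C=C/C(=O)c2ccc(OCC(=O)N[C@H]3CCOC3=O)cc2)cc1`: 6570 nM
Compound 3 `O=C1OCC[C@@H]1NC(=S)SCCOc1ccc(Cl)cc1`: > 64000 nM (a limit, not a number)

Compound 2 is the only one here with a true number, 6570 nM. Compound 1 and compound 3 are known only by the limit of > 64000 nM in this assay, at which 2 of the 3 values shown sit, which is a limit of the test. Going to compound 4 `O=C(COc1ccc(C(=O)/C=C/c2ccc(Br)cc2)cc1)N[C@H]1CCOC1=O` puts bromo in place of tert-butyl on an aromatic carbon, and the rest of the structure stays the same. Among the measured compounds shown here, no measured pair here shows this swap, so this assay offers only one anchor, compound 2 at 6570 nM. The expected change is small and towards weaker inhibition, a 1.4-fold higher number from compound 2 to compound 4 (0.14 log units; within the scatter). For compound 4 the estimate is 9000 nM, with an expected range from 3500 nM to 25000 nM.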

Compound 4, half-maximal inhibitory concentration: 51700 nM
Estimate against measurement, compound 4: 5.7-fold (0.76 log units) below; the measured number lies above the stated range.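

Among the compounds shown here, the change from 4-(tert-butyl)phenyl to 4-bromophenyl gives the only measured step at this position in this assay, a 7.9-fold higher number from compound 2 to compound 4 (0.90 log units; beyond the scatter), so the group at this position clearly affects the reading. With bromo in place, inhibition is weaker, and compound 4 now stands not far short of the point where the test stops giving a number: the limit of > 64000 nM in this assay, at which 2 of the 4 values shown sit.

One step between two groups shows no trend. On these data alone, whether an amine, a carboxylic acid or a methoxy group here would stay close to compound 2 or move further towards compound 4 remains open.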